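The source may report more compounds than this note shows. Statements on the series, on what has been measured and on what is new or still open speak of the compounds shown alone.

Measured so far in a functional assay on A549 cells (Homo sapiens) for inhibition, read by MTT assay, with a stated time of 48 h; a higher number here means a weaker inhibitor, a lower number a stronger inhibitor:
- Compound 1 `Nc1n[nH]c2cccc(-c3cccc(NC(=O)Nc4ccc(Cl)cc4Cl)c3)c12`: > 500000 nM
- Compound 2 `Nc1n[nH]c2cccc(-c3cccc(NC(=O)Nc4nccs4)c3)c12`: > 500000 nM

Compound 2 has no number of its own: its > 500000 nM is a limit of the assay. Compound 1 gives > 500000 nM, which is also a limit. The whole record therefore reads (the limit of > 500000 nM in this assay, at which 2 of the 2 values shown sit). Within the data shown here, the only measured step is a step that the two limits leave unreadable from compound 1 to compound 2, so it offers no size to carry forward.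

Compound 3 `COc1cccc(NC(=O)Nc2cccc(-c3cccc4[nH]nc(N)c34)c2)c1` differs from compound 2 in one place: 3-methoxyphenyl in place of 1,3-thiazol-2-yl on an amide-type nitrogen. The 3-methoxyphenyl enters on the amide-type nitrogen where the 1,3-thiazol-2-yl stood. Neither of the two groups tried there so far has produced a readable number, so no size or direction of change in this assay can be derived from the data, and no real step is expected. Compound 3 is expected to stay close to the limit, and may well be reported only as a limit. The estimated value for compound 3 is 500000 nM, with an expected range of 100000 nM to 1000000 nM. The expected change is thus a number no higher from compound 2 to compound 3 (the limit leaves the size open).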

Compound 3, half-maximal inhibitory concentration: 2490 nM
Compound 3: the middle estimate sits 200-fold (2.30 log units) above what was measured, and the stated range ends above it.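

In this assay, among these compounds, the 3-methoxyphenyl on the amide-type nitrogen gives the first readable number for this series, with an at least 200-fold lower number from compound 2 to compound 3 (2.30 log units; beyond the scatter) and an at least 200-fold lower number from compound 1 to compound 3 (2.30 log units; beyond the scatter). This shows that the group at this one place can decide whether a number can be read at all, which the earlier pair could not show. Having a six-membered aromatic ring there is not enough on its own, as compound 1 carries 2,4-dichlorophenyl at the same place and gives no number, and the step between compound 1 and compound 2 still cannot be read, leaving both compounds at the assay's limit: the limit of > 500000 nM in this assay, at which 2 of the 3 values shown sit.

The compounds shown do not separate the part played by the methoxy group from that of the ring carrying it, nor the loss of the two chlorine atoms from the arrival of the methoxy group, and the full size of both steps also stays open. Whether a plain phenyl, or a phenyl carrying an ethoxy or a hydroxyl group in place of the methoxy, would also give a readable number remains an open question.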